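The compounds below may be only part of what the source reports. "The series", "measured", "known", "first", "only" and "open" are said of these compounds alone.

Working notes on the series. In an ADME assay on J774 cells (Mus musculus) for cytotoxicity, read by resazurin assay, with a stated time of 24 h (on this read-out higher numbers stand for weaker inhibition and lower numbers for stronger inhibition), compound 1 `Cc1ncc([N+](=O)[O-])n1CCCBr` gives 54.8 ug/mL. Compound 2 `Cc1ncc([N+](=O)[O-])n1CCCN1CCCCC1` reads > 100 ug/mL, which is a limit of the assay. Compound 3 `Cc1ncc([N+](=O)[O-])n1CCCCN1CCCCC1` reads > 100 ug/mL, also a limit, so it stands without a number of its own. Compound 4 `Cc1ncc([N+](=O)[O-])n1CCCCCN1CCCC1` differs from compound 3 by (pyrrolidin-1-yl)methyl in place of piperidin-1-yl on a saturated chain carbon, four bonds along the chain from an aromatic nitrogen. Going by the values given here, no measured step covers this exchange directly. The nearest is an at least 1.8-fold higher number from compound 1 to compound 2 (0.26 log units; that floor lies within the scatter). In this assay no step beyond the scatter is expected, resting on that step and on (the limit of > 100 ug/mL in this assay, at which 2 of the 3 values shown sit). The estimated step is a number no higher from compound 3 to compound 4 (the limit leaves the size open). For compound 4 the estimate is 100 ug/mL, with an expected range of 50 ug/mL to 200 ug/mL.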

Compound 4, half-maximal inhibitory concentration: > 100 ug/mL
Compound 4 was reported as a limit (the forecaster's own chance of this, stated with the estimate: 65%); the middle value lies on the limit itself.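

Compound 3 and compound 4 both stand as limits in this assay, so no step can be read between them: the limit of > 100 ug/mL in this assay, at which 3 of the 4 values shown sit.

As far as these compounds go, how compound 2, compound 3 and compound 4 rank against one another stays open.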